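Side-chain variation and tolerated concentration

This account rests on a few compounds, and the source may have more. Where it says the series, first, only, none or still open, it means among the compounds named here.

Compound 3 `O=C1c2ccccc2N(Cc2ccc(Cl)c(Cl)c2)S(=O)(=O)N1Cc1ccccc1` stands at a limit in a functional assay on HEL cells (Homo sapiens) for inhibition; a higher number here means that more compound is tolerated, a lower number that less compound is tolerated: compound 3 gives > 200000 nM, a limit of the assay rather than a number. Compound 1 `O=C1c2ccccc2N(COCc2ccccc2)S(=O)(=O)N1Cc1ccccc1` also sits at a limit; in this assay compound 1 gives > 122000 nM. Among the measured compounds shown here, compound 2 `O=C(OCOCN1c2ccccc2C(=O)N(Cc2ccccc2)S1(=O)=O)c1ccccc1` is the one compound with a number, giving 37000 nM in this assay, and the step of an at least 3.2-fold lower number from compound 1 to compound 2 (0.51 log units; beyond the scatter) shows that a change on the side chain can move the read-out. The step that the two limits leave unreadable from compound 1 to compound 3 concerns the same place as the change now in question, but with both ends at limits, the limit of > 122000 nM in this assay, at which 1 of the 3 values shown sits, and (the limit of > 200000 nM in this assay, at which 1 of the 3 values shown sits), its size cannot be read. Compound 4 `C#CCOCN1c2ccccc2C(=O)N(Cc2ccccc2)S1(=O)=O` differs from compound 3 by propargyloxy in place of 3,4-dichlorophenyl on a saturated chain carbon bound to a sulfonamide nitrogen in a ring. For the measured compounds named here, only that unreadable step bears directly on this place; the readable step sits elsewhere. Compound 4 carries a side chain closer to that of compound 1 than to that of compound 3, so a value near the two limits is expected, with no step beyond the scatter that could be read. Compound 4 is estimated at 150000 nM, range 50000 nM to 400000 nM. The implied step an at least 1.3-fold lower number from compound 3 to compound 4 (0.12 log units; that floor lies within the scatter) is expected to remain within the region set by the limits.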

Compound 4, half-maximal cytotoxic concentration: > 140000 nM
Compound 4 was reported as a limit; the forecaster's own chance of this, stated with the estimate: 60%; the middle value does not contradict the limit.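

Compound 4 gives > 140000 nM in this assay, which is a limit of the assay and not a number. The one readable comparison gives an at least 3.7-fold higher number from compound 2 to compound 4 (0.57 log units; beyond the scatter), so an ethynyl end on the side chain does not bring the lower number seen with the benzoyloxy end, and of the side chains shown only that of compound 2 gives a number. The steps to compound 4 from compound 1 and from compound 3 cannot be read, because both ends of each are limits: the limit of > 140000 nM in this assay, at which 1 of the 4 values shown sits.

Going by these compounds, the order among compound 1, compound 3 and compound 4 stays open, as does how far each lies past its limit. Also open, on these data alone, is whether an amine or a carboxylic acid at the end of this side chain would give a number or a limit.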